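Compound 3 to Compound 4: A Rearranged Ring Pair

A few compounds are considered here, and "the series" means these few. Any claim that something is new, unique, unknown or untested is made for them only; others in the source may bear on it.

Compound 1, `CCOC(=O)C1=C(Nc2ccccc2)S/C(=C\c2ccc(C(=O)O)cc2)C1=O`: 16.8%
Compound 2, `CCOC(=O)C1=C(Nc2ccccc2)S/C(=C\c2cccc(C(=O)O)c2)C1=O`: 50.6%
Compound 3, `CCOC(=O)C1=C(Nc2ccccc2)S/C(=C\c2cc3cccnc3[nH]2)C1=O`: 54.3%

These three compounds share one core and differ only in the group attached to the double-bonded chain carbon. In a functional assay on JAR cells (Homo sapiens) for inhibition, read by MTT assay, with a stated time of 72 h, tested at 10 uM (on this read-out lower numbers stand for less inhibition and higher numbers for more inhibition at the one concentration tested (going by the name of the read-out)), compound 3 gives 54.3%, the highest of the three numbers; compound 2 sits within the scatter of it, while compound 1 lies far below, as a number 37.5 percentage points higher from compound 1 to compound 3 (beyond the scatter) shows.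

Compound 4, `CCOC(=O)C1=C(Nc2ccccc2)S/C(=C\c2cc3ccncc3[nH]2)C1=O`, has not yet been measured. It keeps the same atoms as compound 3 but joins them differently: a group of 9 heavy atoms (7 carbon, 2 nitrogen; one five-membered aromatic ring with 1 hetero atom, one six-membered aromatic ring with 1 hetero atom) in place of a group of 9 heavy atoms (7 carbon, 2 nitrogen; one five-membered aromatic ring with 1 hetero atom, one six-membered aromatic ring with 1 hetero atom), on a double-bonded chain carbon bound to a double-bonded ring carbon.

Among the compounds with values here, no measured step swaps one such nitrogen-containing ring pair for another, so none bears directly on this change. The step from compound 1 to compound 2 shows that moving a group within a ring can matter a great deal, a number 33.8 percentage points higher from compound 1 to compound 2 (beyond the scatter), whereas a number 3.7 percentage points higher from compound 2 to compound 3 (within the scatter) shows that two quite different groups can give almost the same number. The data therefore allow either outcome, and no direction can be called more likely.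

Compound 4 is thus expected to land near compound 3, with a wide range: an estimated 48%, between 20% and 68%, a step of a number 6.3 percentage points lower from compound 3 to compound 4 (within the scatter) that is expected to stay within the scatter.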

Compound 4, a percentage reported as inhibition, at one concentration (the size of the read-out at that concentration, not a potency): 26.3%
Compound 4: middle estimate off by 21.7 percentage points, on the high side; low and high end bracket the measured number.
By their numbers in this assay, from the lowest: compounds 1 and 4 (each within the scatter of the next); then compounds 2 and 3 (each within the scatter of the next).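

Even with the same atoms and the same counts of hydrogen-bond donors and acceptors, rejoining the ring pair on the double-bonded chain carbon gives a number 28 percentage points lower from compound 3 to compound 4 (beyond the scatter) in this assay and so the way the two rings are joined matters at this place, not only what they are made of. The two ring pairs now part ways: the new one shows a number 24.3 percentage points lower from compound 2 to compound 4 (beyond the scatter) against the 3-carboxyphenyl group, yet only a number 9.5 percentage points higher from compound 1 to compound 4 (within the scatter) against the 4-carboxyphenyl group, so a ring pair of this makeup does not by itself keep the number high. Nothing measured here tells what lies behind this difference.

The compounds shown leave open whether a ring pair with no nitrogen in its six-membered ring would give a number closer to compound 3 or to compound 4. They also leave open how an amine or a methyl group added to the six-membered ring of either ring pair would move the number at this one tested concentration.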